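The source may report more compounds than this note shows. Statements on the series, on what has been measured and on what is new or still open speak of the compounds shown alone.

Values so far in a physicochemical assay for solubility (on this read-out lower numbers stand for lower solubility and higher numbers for higher solubility), follow.

Compound 1 `CNC(=O)c1cc(C(=O)N[C@H]2[C@@H]3C[C@@H](O)C[C@@H]32)cc2c1OC[C@H]2c1ccccc1` gives >= 124 ug/mL (a limit)
Compound 2 `CNC(=O)c1cc(C(N)=O)cc2c1OC[C@H]2c1ccccc1` gives >= 144 ug/mL (a limit)

Compound 2 has >= 144 ug/mL as a limit and not as a number. The next step leads to compound 3 `CNC(=O)c1cc(C(=O)NC2CC2)cc2c1OC[C@H]2c1ccccc1` through cyclopropyl in place of hydrogen on an amide-type nitrogen. Going by the values given here, one measured step bears on this change: a step that the two limits leave unreadable from compound 1 to compound 2 on an amide-type nitrogen as well. It gives no size to carry over. Compound 1 carries a group on that nitrogen and shows >= 124 ug/mL as a limit. The estimated step is an at least 1.1-fold lower number from compound 2 to compound 3 (0.04 log units; that floor lies within the scatter) and none beyond the scatter is expected in this assay in either direction. For compound 3 the expected value is 130 ug/mL within an estimated range from 70 ug/mL to 200 ug/mL and the read-out may again be only a limit.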

Compound 3, solubility: >= 190 ug/mL
Compound 3: only a limit was reported (the forecaster's own chance of this, stated with the estimate: 65%); middle value at least 1.4-fold (0.16 log units) away from the limit.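

In this assay compound 3 gives >= 190 ug/mL as a limit. Compound 2 gives >= 144 ug/mL as a limit too. Compound 1 gives >= 124 ug/mL as a limit as well. Going by these compounds alone, no step among compounds 1, 2 and 3 can be read. From the compounds shown here alone, whether any substituent on the amide-type nitrogen shifts this assay at all remains open.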